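One-carbon chain extension at an aromatic oxygen, inhibition

The source may hold more compounds than are shown below. What is called first, only, known or untested is meant among the compounds shown, and "the series" means these compounds.

Of the compounds shown here, two have been measured so far in an assay on cells for binding affinity to vitamin D3 receptor (Homo sapiens), read by fluorescence, tested at 1 uM; a lower number here means less inhibition, a higher number more inhibition at the concentration tested (going by the name of the read-out). Compound 1, `CCC(CC)(c1ccc(OS(=O)(=O)c2ccc(C)cc2)c(C)c1)c1ccc(OCC(O)C(C)(C)C)c(OCC(O)C(C)(C)C)c1`, gives 43% in this assay. Compound 2, `CCC(CC)(c1ccc(OCCO)c(C)c1)c1ccc(OCC(O)C(C)(C)C)c(OCC(O)C(C)(C)C)c1`, gives 38%. On these two numbers compound 2 stands lowest, and its nearest neighbour is compound 1, whose number is a shade higher, a gap that is within the scatter; the step from compound 1 to compound 2, a number 5 percentage points lower from compound 1 to compound 2 (within the scatter), is 2-hydroxyethyl in place of (4-methylphenyl)sulfonyl on an oxygen on an aromatic ring.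

Compound 3, `CCC(CC)(c1ccc(OCCCO)c(C)c1)c1ccc(OCC(O)C(C)(C)C)c(OCC(O)C(C)(C)C)c1`, has not yet been measured. It differs from compound 2 by hydroxymethyl in place of hydroxy on a saturated chain carbon, two bonds along the chain from an oxygen on an aromatic ring, on a saturated chain carbon, two bonds along the chain from an oxygen on an aromatic ring. Going by the values given here, the only measured step touches the same oxygen-bound chain, and a far larger swap there left the number unchanged within the scatter. A one-carbon lengthening is therefore expected to give no step beyond the scatter, no change at the digits printed from compound 2 to compound 3 (within the scatter). Compound 3 is estimated at 38%, between 25% and 51%.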

Compound 3, a percentage reported as inhibition, at one concentration (the size of the read-out at that concentration, not a potency): 76%
Compound 3: middle estimate off by 38 percentage points, on the low side; the measured number lies above the stated range.
By their numbers in this assay, from the lowest: compounds 2 and 1 (each within the scatter of the next); then compound 3.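

In this assay, the length of the chain on this aromatic oxygen clearly matters: turning 2-hydroxyethoxy into 3-hydroxypropoxy, with hydroxymethyl in place of hydroxy, gives a number 38 percentage points higher from compound 2 to compound 3 (beyond the scatter). The earlier step left the number level, yet 3-hydroxypropyl in place of (4-methylphenyl)sulfonyl on the same oxygen gives a number 33 percentage points higher from compound 1 to compound 3 (beyond the scatter), so here a small change in the chain counts for far more than the large swap that stayed within the scatter. Nothing available here accounts for the effect of this added carbon.

The compounds shown leave open whether the rise continues with a longer chain such as 4-hydroxybutyl or is specific to 3-hydroxypropyl, and whether the end of the chain needs its hydroxy at all, which a plain propyl, an amine or a carboxylic acid in that spot would test. Going by these compounds, these are also readings at a single concentration, so how potent compound 3 is remains open.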